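Notes on replacing fluoro with iodo in compound 2

A few compounds are considered here, and "the series" means these few. Any claim that something is new, unique, unknown or untested is made for them only; others in the source may bear on it.

Measured in a functional assay on MCF7 cells (Homo sapiens) for inhibition; on this read-out higher numbers stand for weaker inhibition and lower numbers for stronger inhibition:
- compound 1 `COc1ccc(-c2nc3ccc(F)cc3o2)cc1`: 41000 nM
- compound 2 `COc1ccc(-c2nc3cc(F)ccc3s2)cc1F`: 870 nM

Compound 2 holds the lower of the two numbers in this assay, and so the stronger inhibition. Compound 2 reads 870 nM and compound 1 reads 41000 nM, a gap beyond the usual scatter. These two compounds differ in more than one place, so the gap cannot be assigned to any single structural feature.

The next compound to be tested is compound 3 `COc1ccc(-c2nc3cc(F)ccc3s2)cc1I`. It carries iodo in place of fluoro on an aromatic carbon, ortho to a methoxy group and meta to a large group: iodo in place of fluoro on an aromatic carbon. Going by the values given here, no measured pair shows this exchange, so the expectation has little support and the range is kept wide. Among the compounds with values here, compound 2 at 870 nM is the only anchor, as it is the one measured compound differing from compound 3 in a single place. The expected result is a 1.2-fold lower number from compound 2 to compound 3 (0.09 log units; within the scatter), with no change beyond the scatter and no firm direction. For compound 3 the estimated value is 700 nM, with an expected range of 150 nM to 3500 nM.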

Compound 3, half-maximal inhibitory concentration: 820 nM
Beside the measured number, compound 3's estimate is 1.2-fold (0.07 log units) below it; the range from low to high includes it.
By their numbers in this assay, from the lowest: compounds 3 and 2 (each within the scatter of the next); then compound 1.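

In this assay, going by these compounds alone, the exchange of fluoro for iodo on the aromatic carbon ortho to a methoxy group and meta to a large group gives a 1.1-fold lower number from compound 2 to compound 3 (0.03 log units; within the scatter), the first reading of any exchange at this position. On this read-out fluoro and iodo cannot be told apart here, so the inhibition seen with compound 2 does not depend on fluoro specifically, and a second halogen on this carbon serves equally well, with compound 3 at 820 nM as the new reference point. No measured evidence on why the two halogens read alike is at hand.

The compounds shown cover only these two halogens at this carbon, so it remains open whether a non-halogen group there, such as an amine, a carboxylic acid or a longer alkoxy chain, would hold the number near that of compound 3 or move it beyond the scatter. Also open, on these data alone, is whether a plain hydrogen on this carbon would do the same, a question that would need a compound differing from compound 2 in that one place.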